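The compounds below may be only part of what the source reports. "The series", "measured", "known", "first", "only" and "open" are said of these compounds alone.

Measured so far:
- compound 1, `NC1=NC2(CCOCC2)N(OCCCOc2ccccc2Cl)C(N)=N1`, gives 83.3% in an assay on isolated protein for inhibition of Dihydrofolate reductase (Homo sapiens), read by spectrophotometry, using NADPH, with stated times of 5 s and 6 min, tested at 5 uM; a higher number here means a stronger effect of the compound at the concentration tested, a lower number a weaker effect.
- compound 2, `NC1=NC2(CCOCC2)N(OCCCOc2cc(Cl)c(Cl)cc2Cl)C(N)=N1`, gives > 90% in this assay.

The figure for compound 2 is a limit of the assay rather than a number, so compound 2 stands at the top of the range shown and only that limit is known for it (the limit of > 90% in this assay, at which 1 of the 2 values shown sits).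

Compound 3, `NC1=NC2(CCOCC2)N(OCCCOc2ccc(Br)cc2)C(N)=N1`, differs from compound 2 in one place: 4-bromophenyl in place of 2,4,5-trichlorophenyl on an oxygen on a saturated carbon.

Within the data shown here, the one measured step bearing on this is a number at least 6.7 percentage points higher from compound 1 to compound 2 (that floor lies within the scatter), and it runs the other way round, from 2-chlorophenyl to 2,4,5-trichlorophenyl. Returning to a single halogen on the ring, now 4-bromophenyl, is therefore expected to undo part of that rise in this assay, a modest downward step that may well stay within the scatter. For compound 3 the expected step is a number at least 8 percentage points lower from compound 2 to compound 3 (that floor lies within the scatter). Compound 3 is estimated to give 82%, with a range of 65% to 92%.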

Compound 3, a percentage reported as inhibition, at one concentration (the size of the read-out at that concentration, not a potency): > 90%
Compound 3 ended at the assay's limit (the forecaster's own chance of this, stated with the estimate: 25%); middle value at least 8 percentage points from the limit.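

In this assay compound 3 gives > 90%, which is a limit of the assay and not a number. This shows that, at this position, the ring does not need the three chlorines of 2,4,5-trichlorophenyl to reach the limit, since the single bromine of 4-bromophenyl gets there too, and the comparison with the 2-chlorophenyl group gives a number at least 6.7 percentage points higher from compound 1 to compound 3 (that floor lies within the scatter). The step between the two compounds at the limit cannot be read, so this change can be neither ranked nor sized, because the read-out has run out of room: the limit of > 90% in this assay, at which 2 of the 3 values shown sit.

Going by these compounds, how far apart the compounds at the limit truly lie stays open, and only a measurement that is not capped could separate them. Also open, on these data alone, is what an amine or a carboxylic acid on this ring, or a longer chain leading to it, would do in this assay.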